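Phenyl to imidazolyl in the antiproliferative series

This account rests on a few compounds, and the source may have more. Where it says the series, first, only, none or still open, it means among the compounds named here.

Values in a functional assay on A-375 cells (Homo sapiens) for antiproliferative activity; on this read-out lower numbers stand for stronger inhibition and higher numbers for weaker inhibition:
- Compound 1 `O=C(Nc1ccc(-c2cscn2)cc1)C1CCCN(C(=O)c2ccc(F)c(F)c2)C1`: > 20000 nM (a limit, not a number)
- Compound 2 `O=C(Nc1ccc(-c2cscn2)cc1)[C@@H]1CCCN(Cc2ccc(F)c(F)c2)C1`: 6000 nM
- Compound 3 `O=C(Nc1ccc(-c2ccccc2)cc1)C1CCCN(Cc2ccc(F)c(F)c2)C1`: 2580 nM

Of the two exact values in this assay, compound 3 has the lower number at 2580 nM. Compound 2 stands higher at 6000 nM, a gap beyond the scatter. The value of compound 1 is only a limit.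

The next compound to be measured is compound 4 `O=C(Nc1ccc(-c2c[nH]cn2)cc1)C1CCCN(Cc2ccc(F)c(F)c2)C1`, which carries 1H-imidazol-4-yl in place of the phenyl of compound 3 on an aromatic carbon: 1H-imidazol-4-yl in place of phenyl on an aromatic carbon.

Within the data shown here, no measured step isolates this change, so the expectation is tentative. Compound 2 at 6000 nM also has a five-membered aromatic ring with 2 hetero atoms on that aromatic carbon, and its number is higher than that of compound 3. A moderate rise beyond the scatter is therefore expected in this assay, with an estimated step of a 3.1-fold higher number from compound 3 to compound 4 (0.49 log units; beyond the scatter).

The estimated value for compound 4 is 8000 nM, with an expected range from 2500 nM to 20000 nM.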

Compound 4, half-maximal inhibitory concentration: > 20000 nM
Compound 4 gave a limit, no number; the forecaster's own chance of this, stated with the estimate: 20%; middle value at least 2.5-fold (0.39 log units) away from the limit.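

In this assay, among these compounds, 1H-imidazol-4-yl in place of phenyl gives an at least 7.7-fold higher number from compound 3 to compound 4 (0.88 log units; beyond the scatter), the first step that isolates a single change at this position. Compound 4 gives > 20000 nM, which is a limit and not a number, and the step therefore marks only a minimum size: the limit of > 20000 nM in this assay, at which 2 of the 4 values shown sit. At this position, on an aromatic carbon para to a large group, this one ring change is enough to move the series from a measurable number to the limit of the read-out.

From the compounds shown here alone, whether the loss follows the hydrogen-bond donor that enters with 1H-imidazol-4-yl or the change of ring remains open. A methyl group on the ring nitrogen of the imidazole, or a pyridyl ring in place of phenyl, would help to separate the two.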